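Chloro to bromo on the aryl carbonyl arm

The source may hold more compounds than are shown below. What is called first, only, known or untested is meant among the compounds shown, and "the series" means these compounds.

Compound 1 `CC(=O)N(C)c1ccc2[nH]c(-c3n[nH]c4ccccc34)cc2n1`: > 50000 nM, a limit of the assay.
Compound 2 `CN(C(=O)c1ccccc1)c1ccc2[nH]c(-c3n[nH]c4ccccc34)cc2n1`: 13800 nM.
Compound 3 `CN(C(=O)c1ccc(Cl)cc1)c1ccc2[nH]c(-c3n[nH]c4ccccc34)cc2n1`: 2220 nM.

In a functional assay on A549 cells (Homo sapiens) for antiproliferative activity, read by MTT assay, with a stated time of 72 h (on this read-out higher numbers stand for weaker inhibition and lower numbers for stronger inhibition), compound 3 gives 2220 nM, the lowest number among the measured compounds. Its nearest neighbour is compound 2, separated by a 6.2-fold lower number from compound 2 to compound 3 (0.79 log units; beyond the scatter). Compound 1 sits at the limit of this assay (the limit of > 50000 nM in this assay, at which 1 of the 3 values shown sits). Compound 4 `CN(C(=O)c1ccc(Br)cc1)c1ccc2[nH]c(-c3n[nH]c4ccccc34)cc2n1` differs from compound 3 by bromo in place of chloro on an aromatic carbon. The measured steps are of another kind: an at least 3.6-fold lower number from compound 1 to compound 2 (0.55 log units; beyond the scatter) and an at least 22-fold lower number from compound 1 to compound 3 (1.35 log units; beyond the scatter) replace methyl with an aryl group, and a 6.2-fold lower number from compound 2 to compound 3 (0.79 log units; beyond the scatter) adds chloro where hydrogen stood. None of them compares chloro with bromo, so the expectation rests on the halogen exchange alone and is for a step within the scatter, a 1.2-fold lower number from compound 3 to compound 4 (0.09 log units; within the scatter). Compound 4 is therefore estimated at 1800 nM, with a range from 600 nM to 5500 nM.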

Compound 4, half-maximal inhibitory concentration: 4250 nM
Beside the measured number, compound 4's estimate is 2.4-fold (0.37 log units) below it, and the stated range covers the measured number.
By their numbers in this assay, from the lowest: compounds 3 and 4 (each within the scatter of the next); then compound 2. At a limit, above all of these: compound 1.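

On the aromatic carbon para to a large group, the exchange of chloro for bromo separates the two halogens by no more than the scatter, with a 1.9-fold higher number from compound 3 to compound 4 (0.28 log units; within the scatter). Bromo still stands clear of hydrogen at this place, with a 3.2-fold lower number from compound 2 to compound 4 (0.51 log units; beyond the scatter), so the effect of chloro in compound 3 is not unique to that halogen. The 4-bromophenyl group in place of methyl gives an at least 11-fold lower number from compound 1 to compound 4 (1.07 log units; beyond the scatter), and this step rests on a limit for compound 1: the limit of > 50000 nM in this assay, at which 1 of the 4 values shown sits.

The compounds shown leave open whether fluoro, methoxy or an amine at this place would match the two halogens. They also leave open how a bromo on another carbon of that ring would read.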